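The compounds below may be only part of what the source reports. "The series", "measured", "known", "first", "only" and "open" are said of these compounds alone.

Measured compounds:
Compound 1, `O=C(NS(=O)(=O)CCNC(=O)C1CC1)c1ccc(Nc2nc(NC3(c4ccc(Cl)cc4)CC3)nc(OCC(F)(F)F)n2)cc1`, in an ADME assay on microsomes from liver (Rattus norvegicus) for metabolic stability, with a stated time of 10 min; a higher number here means that more of the compound is left, a lower number that less of the compound is left: "not active" (no number reported)
Compound 2, `O=C(NS(=O)(=O)C1CC1)c1ccc(Nc2nc(NC3(c4ccc(Cl)cc4)CC3)nc(OCC(F)(F)F)n2)cc1`, in this assay: 85%

Compound 2 is the only one of the two with a number in this assay; it stands alone. Compound 1 has no number to set against it. Compound 3, `CC(=O)NCCS(=O)(=O)NC(=O)c1ccc(Nc2nc(NC3(c4ccc(Cl)cc4)CC3)nc(OCC(F)(F)F)n2)cc1`, is not yet measured. It differs from compound 2 in one place: 2-acetamidoethyl in place of cyclopropyl on a sulfonyl sulfur. Compound 1 carries a chain of the same kind on the same sulfonyl sulfur, and for compound 1 this assay gives "not active" (no number reported), without a figure. Among the measured compounds shown here, no step between measured compounds is known here. The step from compound 2 to compound 3 is expected to be a modest loss, likely beyond the scatter, as a number 20 percentage points lower from compound 2 to compound 3 (beyond the scatter). Compound 3 is estimated at 65%, between 35% and 90%.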

Compound 3, percent of the compound remaining: 100%
Beside the measured number, compound 3's estimate is 35 percentage points below it; measured number outside the range, above it.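

In this assay the change from a small carbon ring to an open chain carrying an amide on the sulfonyl sulfur gives a number 15 percentage points higher from compound 2 to compound 3 (beyond the scatter) and so does not cost stability in this test. Among the compounds shown here, this is the first number for such a chain at this position, as compound 1 carries a chain of the same kind but has no figure. It shows that the cyclopropyl ring is not needed here for the compound to remain in the microsomal mixture. Nothing measured here accounts for the difference.

With no number for compound 1, the effect of the group at the end of the chain cannot be judged. As far as these compounds go, whether a plain ethyl group, a longer chain, or a chain ending in an amine or a carboxylic acid would fare as well also stays open.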